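The source may report more compounds than this note shows. Statements on the series, on what has been measured and on what is new or still open speak of the compounds shown alone.

Compounds measured so far:
compound 1 `O=C1C=C[C@@H](OCc2ccccc2)[C@@H]([C@@H](COC(=O)/C=C/c2ccccc2)OCc2ccccc2)O1`, 4960 nM
compound 2 `O=C1C=C[C@@H](OCc2ccccc2)[C@@H]([C@@H](COC(=O)/C=C/c2ccc(F)cc2)OCc2ccccc2)O1`, 4160 nM
compound 3 `CC(=O)OC[C@@H](OC(C)=O)[C@H]1OC(=O)C=C[C@H]1OC(C)=O`, 24600 nM

In a functional assay on Jurkat cells (Homo sapiens) for antiproliferative activity, read by MTT assay, with a stated time of 6 days (on this read-out higher numbers stand for weaker inhibition and lower numbers for stronger inhibition), compound 2 has the lowest number of the three; against compound 1 the gap, a 1.2-fold lower number from compound 1 to compound 2 (0.08 log units; within the scatter), sits within the scatter, while compound 3 lies beyond it. Compound 4 `CC(=O)OC[C@@H](OCc1ccccc1)[C@H]1OC(=O)C=C[C@H]1OCc1ccccc1` differs from compound 2 by methyl in place of 2-(4-fluorophenyl)ethenyl on a carbonyl carbon. For the measured compounds named here, no measured step covers this change; compound 3 carries acetyl groups throughout and gives a higher number than compound 2, yet it differs from compound 2 in more than one place, so only the two values can be compared. Compound 4 is therefore expected to show a moderate rise, a 2.4-fold higher number from compound 2 to compound 4 (0.38 log units; beyond the scatter), with compound 4 estimated at 10000 nM, in the range 4000 nM to 30000 nM.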

Compound 4, half-maximal inhibitory concentration: 14700 nM
The estimate for compound 4 lay 1.5-fold (0.17 log units) below the measured number, within the range that was stated.
By their numbers in this assay, from the lowest: compounds 2 and 1 (each within the scatter of the next); then compounds 4 and 3 (each within the scatter of the next).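

In this assay the change to acetoxy on this carbonyl carbon now has a measured size, with a 3.5-fold higher number from compound 2 to compound 4 (0.55 log units; beyond the scatter) and with a 3.0-fold higher number from compound 1 to compound 4 (0.47 log units; beyond the scatter) as well. Both steps lie beyond the scatter, so the higher number with methyl appears whether the group that leaves is 2-(4-fluorophenyl)ethenyl or 2-phenylethenyl. No measurement here gives a reason for this step.

The compounds shown do not separate the aromatic ring from the double bond outside it, which a 2-phenylethyl group on this carbonyl carbon would address. On these data alone, an amine on that aromatic ring also remains open.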